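The source may report more compounds than this note shows. Statements on the series, on what has been measured and on what is new or still open speak of the compounds shown alone.

Measured compounds:
compound 1 `COc1cc(OC)c(C(=O)/C=C/c2ccccc2SC)c(OC)c1`, 2.2%
compound 2 `COc1cc(OC)c(C(=O)/C=C/c2ccccc2)c(OC)c1`, 24%

Both numbers come from a functional assay on Caco-2 cells (Homo sapiens), read by fluorescence and BrdU incorporation, with a stated time of 48 h, tested at 25 uM; a lower number here means a stronger effect, a higher number a weaker effect of the compound at the concentration tested. Among the compounds with values here, compound 1 stands lowest of the two values, with compound 2 the nearest neighbour, and the only measured step is a number 21.8 percentage points higher from compound 1 to compound 2 (beyond the scatter), which is beyond the scatter and modest in size. Compound 3 `COc1cc(OC)c(C(=O)/C=C/c2ccc(F)cc2)c(OC)c1` has not yet been measured. It differs from compound 1 in one place: 4-fluorophenyl in place of 2-(methylsulfanyl)phenyl on a double-bonded chain carbon bound to a double-bonded chain carbon. That step bears on the measured one only in part: the measured step removes the methylsulfanyl altogether, whereas here the whole aryl group is exchanged and a fluorine arrives on a different carbon, so the measured step is a guide rather than a match. A weakening of similar size to the measured step is expected, in the upward direction. Compound 3 is therefore estimated at 25%, with a range from 8% to 45%, which as a step means a number 22.8 percentage points higher from compound 1 to compound 3 (beyond the scatter).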

Compound 3, a percentage reported as activity, at one concentration (the size of the read-out at that concentration, not a potency): 13%
Compound 3: the middle estimate sits 12 percentage points above what was measured; the range from low to high includes it.
By their numbers in this assay, from the lowest: compound 1; then compound 3; then compound 2.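

In this assay, a single fluoro in place of hydrogen on an aromatic carbon is enough to change the result, giving a number 11 percentage points lower from compound 2 to compound 3 (beyond the scatter). So methylsulfanyl is not the only group at this end of the molecule that lowers the number, although 4-fluorophenyl in place of 2-(methylsulfanyl)phenyl still gives a number 10.8 percentage points higher from compound 1 to compound 3 (beyond the scatter), which leaves compound 3 between the other two. No measurement shown explains why these groups differ.

Because methylsulfanyl and fluoro sit on different carbons of the aromatic ring, these compounds cannot separate the effect of the group itself from the effect of where it sits. On these data alone, how an amine or a carboxylic acid on this ring would shift the number also remains open.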